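Swapping a fluorophenyl for a dimethoxyphenyl on the core

A few compounds are considered here, and "the series" means these few. Any claim that something is new, unique, unknown or untested is made for them only; others in the source may bear on it.

Measured so far:
Compound 1, `O=C(Nc1ccccc1C(=O)O/N=C1\CCCc2onc(-c3ccc(F)cc3)c21)c1cccc(F)c1`: > 25000 nM
Compound 2, `O=C(Nc1cccc(C(=O)O/N=C2\CCCc3onc(-c4cccc(F)c4)c32)c1)c1cccc(F)c1`: 4700 nM
Compound 3, `COc1ccc(-c2onc3c2/C(=N/OC(=O)c2cccc(NC(=O)c4cccc(F)c4)c2)CC(C)(C)C3)cc1OC`: > 25000 nM

Among the measured compounds shown here, in a functional assay on MCF7 cells (Homo sapiens) for antiproliferative activity, read by MTT assay, with a stated time of 72 h (a higher number here means a weaker inhibitor, a lower number a stronger inhibitor), compound 2 gives 4700 nM, the only number reported among the three. Compound 1 reaches only the limit of this assay at > 25000 nM. Compound 3 likewise sits at the limit, > 25000 nM. Compound 4, `COc1ccc(-c2noc3c2/C(=N/OC(=O)c2cccc(NC(=O)c4cccc(F)c4)c2)CCC3)cc1OC`, has not yet been tested; it differs from compound 2 by 3,4-dimethoxyphenyl in place of 3-fluorophenyl on an aromatic carbon. For the measured compounds named here, no pair of measured compounds differs in just one place, so no step can be read off directly. Compound 3 carries the same 3,4-dimethoxyphenyl and stops at the limit (the limit of > 25000 nM in this assay, at which 2 of the 3 values shown sit), which hints that the change may weaken activity. The expected step from compound 2 to compound 4 is a 2.6-fold higher number from compound 2 to compound 4 (0.41 log units; beyond the scatter). Compound 4 is therefore estimated at 12000 nM, within 3500 nM to 30000 nM.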

Compound 4, half-maximal inhibitory concentration: > 25000 nM
Compound 4 was reported as a limit; the forecaster's own chance of this, stated with the estimate: 40%; middle value at least 2.0-fold (0.31 log units) away from the limit.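

In this assay, putting 3,4-dimethoxyphenyl in place of 3-fluorophenyl on this aromatic carbon of the five-membered ring gives an at least 5.3-fold higher number from compound 2 to compound 4 (0.72 log units; beyond the scatter). Among the compounds shown here, this is the only single change that can be read directly, and it shows that activity at this position does not survive the swap. Compound 4 stands at a limit, so the step gives only a minimum size: the limit of > 25000 nM in this assay, at which 3 of the 4 values shown sit.

As far as these compounds go, whether one methoxy group alone would cost as much stays open. So does the outcome with a plain phenyl or an aminophenyl on this carbon.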